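Bromo for fluoro on the aryl ring of compound 3

A few compounds are considered here, and "the series" means these few. Any claim that something is new, unique, unknown or untested is made for them only; others in the source may bear on it.

Of the compounds shown here, three sharing one core have been tested in a functional assay on MKN-45 cells (Homo sapiens) for cytotoxicity, read by MTT assay, with a stated time of 72 h; on this read-out lower numbers stand for stronger inhibition and higher numbers for weaker inhibition. Compound 2 `COc1cc2c(Oc3ccc(NC(=O)c4nn(-c5ccccc5)c(=O)c5ccccc45)cc3F)ccnc2cc1OCCCN1CCN(C)CC1` gives 620 nM. Compound 3 `COc1cc2c(Oc3ccc(NC(=O)c4nn(-c5ccc(F)cc5)c(=O)c5ccccc45)cc3F)ccnc2cc1OCCCN1CCN(C)CC1` gives 150 nM. Compound 1 `COc1cc2c(Oc3ccc(NC(=O)c4nn(-c5ccc(Br)cc5)c(=O)c5ccccc45)cc3F)ccnc2cc1OCCCN1CCCC1` gives 230 nM. On these numbers compound 3 carries the lowest value of the three, though its gap to compound 1 lies within the scatter, so the two cannot be ordered. Going by the values given here, the one single-point step in the set, a 4.1-fold lower number from compound 2 to compound 3 (0.62 log units; beyond the scatter), shows that the fluoro group made a clear difference against hydrogen.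

Compound 4 `COc1cc2c(Oc3ccc(NC(=O)c4nn(-c5ccc(Br)cc5)c(=O)c5ccccc45)cc3F)ccnc2cc1OCCCN1CCN(C)CC1` is not yet measured. It differs from compound 3 by bromo in place of fluoro on an aromatic carbon. Among the compounds with values here, no measured step changes fluoro to bromo at this place. The nearest bearing comes from compound 1, which carries the same bromo group on a different tail and sits within the scatter of compound 3. Compound 4 is therefore expected to stay close to compound 3, with a step of a 1.3-fold higher number from compound 3 to compound 4 (0.12 log units; within the scatter) that is not beyond the scatter. The estimate for compound 4 is 200 nM, within 80 nM to 500 nM.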

Compound 4, half-maximal inhibitory concentration: 350 nM
Compound 4: middle estimate off by 1.8-fold (0.24 log units), on the low side; measured number inside the range.
By their numbers in this assay, from the lowest: compounds 3, 1, 4 and 2 (each within the scatter of the next, the first and the last beyond it).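

In this assay, the two halogens are not interchangeable on this aryl ring: a 2.3-fold higher number from compound 3 to compound 4 (0.37 log units; beyond the scatter) shows that the change from 4-fluorophenyl to 4-bromophenyl goes beyond the scatter. Bromo also does not separate clearly from hydrogen at this place, since a 1.8-fold lower number from compound 2 to compound 4 (0.25 log units; within the scatter) lies within the scatter, whereas a 4.1-fold lower number from compound 2 to compound 3 (0.62 log units; beyond the scatter) lies beyond it for fluoro. The tail change gives a 1.5-fold higher number from compound 1 to compound 4 (0.18 log units; within the scatter) and also lies within the scatter, so with bromo on the aryl ring, 4-methylpiperazin-1-yl and pyrrolidin-1-yl cannot be told apart here.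

Nothing available explains the difference between fluoro and bromo at this place. As far as these compounds go, it remains open whether chloro or a nitrile at the same place would read like fluoro or like bromo, and whether the tail change would also stay within the scatter with 4-fluorophenyl.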